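The source may report more compounds than this note shows. Statements on the series, on what has been measured and on what is new or still open speak of the compounds shown alone.

Of the compounds shown here, three sharing one core have been measured so far. Compound 1 `CN(C)C(=O)c1cc2cnc(Nc3ccc(NC(=O)C4(C(=O)Nc5ccc(Cl)cc5)CC4)cc3)nc2n1C1CCCC1` gives 101% in a functional assay on A549 cells (Homo sapiens) for inhibition, read by CCK-8 assay, with a stated time of 72 h, tested at 10 uM (a lower number here means less inhibition of growth, a higher number more inhibition of growth at the concentration tested), and stands highest of the three, with both other values beyond the scatter below it. Compound 2 `CN(C)C(=O)c1cc2cnc(Nc3ccc(NC(=O)C4(C(=O)Nc5cccc(Cl)c5)CC4)cc3)nc2n1C1CCCC1` gives 90.7% in this assay, and compound 3 `Cc1ccc(NC(=O)C2(C(=O)Nc3ccc(Nc4ncc5cc(C(=O)N(C)C)n(C6CCCC6)c5n4)cc3)CC2)cc1` gives 90.6%. The step of a number 10.3 percentage points lower from compound 1 to compound 2 (beyond the scatter) follows from 3-chlorophenyl in place of 4-chlorophenyl on an amide-type nitrogen, and the step of a number 10.4 percentage points lower from compound 1 to compound 3 (beyond the scatter) from methyl in place of chloro on an aromatic carbon. The remaining step, a number 0.1 percentage points lower from compound 2 to compound 3 (within the scatter), adds no further lead.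

Compound 4 `COC(=O)c1cccc(NC(=O)C2(C(=O)Nc3ccc(Nc4ncc5cc(C(=O)N(C)C)n(C6CCCC6)c5n4)cc3)CC2)c1` has not yet been measured. It differs from compound 1 in one place: 3-(methoxycarbonyl)phenyl in place of 4-chlorophenyl on an amide-type nitrogen. Both measured steps away from compound 1 alter the same 4-chlorophenyl group that leaves here, and each lowered the read-out by a modest amount beyond the scatter. Going by the values given here, no measured compound carries the incoming 3-(methoxycarbonyl)phenyl group, so the guidance is indirect. A modest fall is therefore expected, and the step of a number 13 percentage points lower from compound 1 to compound 4 (beyond the scatter) is the estimated outcome. For compound 4 the expected value in this assay is 88%, with a range from 72% to 100%.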

Compound 4, percent growth inhibition at one concentration: 91%
The estimate for compound 4 lay 3 percentage points below the measured number; measured number inside the range.
By their numbers in this assay, from the lowest: compounds 3, 2, 4 and 1 (each within the scatter of the next, the first and the last beyond it).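

The ring on this amide-type nitrogen can carry a much larger substituent than chloro or methyl, and one with hydrogen-bond acceptors, without a change that can be told from the scatter: 3-(methoxycarbonyl)phenyl in place of 4-chlorophenyl gives a number 10 percentage points lower from compound 1 to compound 4 (within the scatter) in this assay. Methoxycarbonyl in place of chloro gives a number 0.3 percentage points higher from compound 2 to compound 4 (within the scatter), and 3-(methoxycarbonyl)phenyl in place of 4-methylphenyl gives a number 0.4 percentage points higher from compound 3 to compound 4 (within the scatter), so these three changes of the ring do not separate compounds 2, 3 and 4 from one another, and the apparent edge of compound 1 no longer holds against every other compound. Nothing available explains why this larger group is accepted here.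

The compounds shown leave open how a carboxylic acid or an amine on this phenyl ring would read, and whether a longer chain on the ester would still be accepted. With a single tested concentration and values this close together, they also leave open whether compounds 1 and 4 would differ in a full dose-response measurement.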